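Compound 3 to compound 4: a benzyl swap

A few compounds are considered here, and "the series" means these few. Any claim that something is new, unique, unknown or untested is made for them only; others in the source may bear on it.

compound 1 `CC1=CC[C@H]2[C@@H]1CC=C(C)[C@@H](CC[C@H]1[C@]3(C)CC[C@H](OC(=O)CCC(=O)O)C(C)(C)O[C@H]3CC[C@@]1(C)O)C2(C)C` 29600 nM
compound 2 `CC1=CC[C@H]2[C@@H]1CC=C(C)[C@@H](CC[C@H]1[C@]3(C)CC[C@H](OC(=O)c4ccc(C)cc4)C(C)(C)O[C@H]3CC[C@@]1(C)O)C2(C)C` 32700 nM
compound 3 `CC1=CC[C@H]2[C@@H]1CC=C(C)[C@@H](CC[C@H]1[C@]3(C)CC[C@H](OC(=O)c4ccc(Cl)cc4)C(C)(C)O[C@H]3CC[C@@]1(C)O)C2(C)C` 12700 nM

In a functional assay on MDA-MB-231 cells (Homo sapiens) for antiproliferative activity, read by MTT assay, with a stated time of 72 h (a higher number here means a weaker inhibitor, a lower number a stronger inhibitor), compound 3 has the lowest number of the three. Compound 4 `CC1=CC[C@H]2[C@@H]1CC=C(C)[C@@H](CC[C@H]1[C@]3(C)CC[C@H](OCc4ccccc4)C(C)(C)O[C@H]3CC[C@@]1(C)O)C2(C)C` has benzyl in place of (4-chlorophenyl)carbonyl on an oxygen on a saturated carbon. Going by the values given here, no measured step makes this change. The nearest steps are modest (a 2.3-fold lower number from compound 1 to compound 3 (0.37 log units; beyond the scatter); a 2.6-fold lower number from compound 2 to compound 3 (0.41 log units; beyond the scatter)), and one stays within the scatter (a 1.1-fold higher number from compound 1 to compound 2 (0.04 log units; within the scatter)). Compound 4 carries no chloro, and the measured compounds without it have higher numbers. For compound 4 a modest rise is therefore expected (a 1.7-fold higher number from compound 3 to compound 4 (0.24 log units; within the scatter)). The expected value for compound 4 is 22000 nM with an estimated range of 9000 nM to 55000 nM in this assay on this reasoning.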

Compound 4, half-maximal inhibitory concentration: 35700 nM
The estimate for compound 4 lay 1.6-fold (0.21 log units) below the measured number, within the range that was stated.
By their numbers in this assay, from the lowest: compound 3; then compounds 1, 2 and 4 (each within the scatter of the next).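

In this assay benzyl on this oxygen gives a 2.8-fold higher number from compound 3 to compound 4 (0.45 log units; beyond the scatter) but stays level with the two other esters, with a 1.1-fold higher number from compound 2 to compound 4 (0.04 log units; within the scatter) and a 1.2-fold higher number from compound 1 to compound 4 (0.08 log units; within the scatter) both within the scatter. The carbonyl on this oxygen is thus not needed to reach that level, and among these four compounds only compound 3, which carries the chloro, stands apart. No measurement here accounts for this result.

Going by these compounds, whether a 4-chlorobenzyl group on this oxygen would match compound 3 stays open. So does the effect of an amine on this oxygen.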